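A few compounds are considered here, and "the series" means these few. Any claim that something is new, unique, unknown or untested is made for them only; others in the source may bear on it.

Measured compounds:
- compound 1 `COC(=O)[C@@]1(C)CCC=C2[C@@H]1CC[C@@H](C)[C@]2(C)Cc1c[nH]c2ccccc12`: in a functional assay on WiDr cells (Homo sapiens) for inhibition, read by sulforhodamine B assay, with a stated time of 48 h (on this read-out lower numbers stand for stronger inhibition of growth and higher numbers for weaker inhibition of growth), compound 1 gives 8700 nM
- compound 2 `COC(=O)[C@@]1(C)CCC=C2[C@@H]1CC[C@@H](C)[C@]2(C)Cc1c(C)[nH]c2ccccc12`: compound 2 gives 19000 nM
- compound 3 `COC(=O)[C@@]1(C)CCC=C2[C@@H]1CC[C@@H](C)[C@]2(C)Cc1c(C)[nH]c2c(Br)cccc12`: compound 3 gives 38000 nM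

Compound 2 holds the second highest of the three numbers in this assay. Its nearest neighbour is compound 3, reached by bromo in place of hydrogen on an aromatic carbon, a step of a 2.0-fold higher number from compound 2 to compound 3 (0.30 log units; within the scatter). The step from compound 1, methyl in place of hydrogen on an aromatic carbon, is a 2.2-fold higher number from compound 1 to compound 2 (0.34 log units; beyond the scatter), a modest move to weaker growth inhibition.

Compound 4 `COC(=O)[C@@]1(C)CCC=C2[C@@H]1CC[C@@H](C)[C@]2(C)Cc1c(C=O)[nH]c2ccccc12` differs from compound 2 by formyl in place of methyl on an aromatic carbon. Among the compounds with values here, of the measured steps, only the one from compound 1 touches the group that is now exchanged, and it was modest; the step to compound 3 concerns a different place and stayed within the scatter. Within the data shown here, no measured step brings in a formyl or any hydrogen-bond acceptor, so there is no direct precedent. Within this series the changes so far have moved the numbers only modestly, and the same is expected here: a step of a 1.2-fold lower number from compound 2 to compound 4 (0.07 log units; within the scatter) in this assay, not clearly beyond the scatter in either direction. Compound 4 is therefore estimated at 16000 nM, with a range from 6000 nM to 45000 nM.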

Compound 4, concentration for 50% growth inhibition: 20000 nM
The estimate for compound 4 lay 1.3-fold (0.10 log units) below the measured number; measured number inside the range.
By their numbers in this assay, from the lowest: compound 1; then compounds 2, 4 and 3 (each within the scatter of the next).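

In this assay, the exchange of methyl for formyl on this aromatic carbon, next to the ring nitrogen, gives a 1.1-fold higher number from compound 2 to compound 4 (0.02 log units; within the scatter), so the hydrogen-bond acceptor that enters with the formyl leaves the number within the scatter of the methyl compound. Measured against hydrogen at the same carbon, the formyl gives a 2.3-fold higher number from compound 1 to compound 4 (0.36 log units; beyond the scatter) and the methyl gives a 2.2-fold higher number from compound 1 to compound 2 (0.34 log units; beyond the scatter): both groups shown at this place lie beyond the scatter from hydrogen and in the same direction, towards weaker growth inhibition, which makes the hydrogen of compound 1 the only one of these three substituents set apart by its number. No measurement is available that would explain either step.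

The compounds shown leave open whether an amine, a carboxylic acid or a longer alkyl chain at this carbon would stay with methyl and formyl or give a number lower than that of compound 1. From the compounds shown here alone, it also remains open whether the bromo step seen from compound 2 to compound 3 would read the same with a formyl in place of the methyl.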